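This account rests on a few compounds, and the source may have more. Where it says the series, first, only, none or still open, it means among the compounds named here.

Notes on the series. Compound 1 `COC(=O)c1cc2cc(NCc3cc(NC(=O)c4ccc(CN5CCC(N(C)C)C5)c(C(F)(F)F)c4)ccc3C)cnc2[nH]1` and compound 2 `CC(=O)c1cc2cc(NCc3cc(NC(=O)c4ccc(CN5CCC(N(C)C)C5)c(C(F)(F)F)c4)ccc3C)cnc2[nH]1` share one core. In a functional assay on HUVEC cells (Homo sapiens), read by MTT assay, with a stated time of 72 h (a lower number here means that less compound is needed, a higher number that more compound is needed for the effect), compound 1 gives 689 nM, and compound 2 gives 97 nM. The change between them is methyl in place of methoxy on a carbonyl carbon, and it gave a 7.1-fold lower number from compound 1 to compound 2 (0.85 log units; beyond the scatter). Compound 3 `COC(=O)c1cc2cc(CCc3cc(NC(=O)c4ccc(CN5CCC(N(C)C)C5)c(C(F)(F)F)c4)ccc3C)cnc2[nH]1` sits on a second core; the difference between the two cores is not broken down here. In this assay compound 3 gives 171 nM. Compound 4 `CC(=O)c1cc2cc(CCc3cc(NC(=O)c4ccc(CN5CCC(N(C)C)C5)c(C(F)(F)F)c4)ccc3C)cnc2[nH]1` is not yet measured. It differs from compound 3 by methyl in place of methoxy on a carbonyl carbon, the same change as before, at a place described in the same words. For the measured compounds named here, the step expected in this assay is a 3.8-fold lower number from compound 3 to compound 4 (0.58 log units; beyond the scatter), a gain set somewhat smaller than the earlier one since only a single prior instance, a 7.1-fold lower number from compound 1 to compound 2 (0.85 log units; beyond the scatter), supports it and it lies on a different core. Compound 4 is estimated at 45 nM, between 15 nM and 130 nM.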

Compound 4, half-maximal effective concentration: 163 nM
The estimate for compound 4 lay 3.6-fold (0.56 log units) below the measured number; the measured number lies above the stated range.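

In this assay, methyl in place of methoxy on a carbonyl carbon gives a 1.0-fold lower number from compound 3 to compound 4 (0.02 log units; within the scatter), so on the core of compound 3 the step cannot be told from the scatter. The step seen on the core of compound 1 therefore did not carry over to this second core, and the two steps differ: the same change on two cores in this assay, a 7.1-fold lower number (0.85 log units; beyond the scatter) from compound 1 to compound 2 and a 1.0-fold lower number (0.02 log units; within the scatter) from compound 3 to compound 4, 6.8-fold (0.83 log units) apart, beyond the scatter of two such steps. With a single pair on each core, this shows that the result of the swap was not the same on these two cores, but it does not show which part of the difference between the cores is responsible, or how the swap would behave on a third core.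

As far as these compounds go, it remains open whether an amine or a longer chain such as ethyl on the same carbonyl carbon would separate the two cores in the same way.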